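A Dichlorophenyl Swap on an Aromatic Nitrogen

The source may hold more compounds than are shown below. What is called first, only, known or untested is meant among the compounds shown, and "the series" means these compounds.

For the measured compounds named here, compound 1 (`Clc1cccc(Nc2ncc3cccc(OCc4cn(-c5ccc(Br)cc5)nn4)c3n2)c1`) gives 14000 nM in a functional assay on Huh-7 cells (Homo sapiens) for cytotoxicity, read by cell counting, with a stated time of 48 h (a lower number here means a stronger inhibitor, a higher number a weaker inhibitor), and compound 2 (`COc1cccc(-n2cc(COc3cccc4cnc(Nc5cccc(Cl)c5)nc34)nn2)c1`) gives 23000 nM there, which places compound 2 within the scatter of its only measured neighbour. Compound 3 (`Clc1cccc(Nc2ncc3cccc(OCc4cn(-c5cc(Cl)cc(Cl)c5)nn4)c3n2)c1`) carries 3,5-dichlorophenyl in place of 3-methoxyphenyl on an aromatic nitrogen and is not yet measured. Going by the values given here, the one measured step at that place is a 1.6-fold higher number from compound 1 to compound 2 (0.22 log units; within the scatter) and it gives no ground to expect a step beyond the scatter in this assay here. The estimate is a 1.4-fold lower number from compound 2 to compound 3 (0.16 log units; within the scatter) as the expected step. For compound 3 the expected value is 16000 nM with an estimated range of 6000 nM to 40000 nM for now.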

Compound 3, half-maximal inhibitory concentration: 7000 nM
Compound 3: the middle estimate sits 2.3-fold (0.36 log units) above what was measured; measured number inside the range.
By their numbers in this assay, from the lowest: compounds 3, 1 and 2 (each within the scatter of the next, the first and the last beyond it).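

In this assay, this place on the aromatic nitrogen now shows a step beyond the scatter: 3,5-dichlorophenyl in place of 3-methoxyphenyl gives a 3.3-fold lower number from compound 2 to compound 3 (0.52 log units; beyond the scatter) and this step is modest. The same group in place of 4-bromophenyl gives a 2.0-fold lower number from compound 1 to compound 3 (0.30 log units; within the scatter) and stays within the scatter, so only compound 2 and compound 3 stand apart. Nothing available explains the size of either step.

Still open, going by these compounds, is whether an aryl group bearing an amine or a carboxylic acid would move the number further at this place. Also open, on these data alone, is whether a saturated ring such as cyclohexyl could stand in for the aryl group.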